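This account rests on a few compounds, and the source may have more. Where it says the series, first, only, none or still open, it means among the compounds named here.

Working notes on the series, read in a functional assay on DU-145 cells (Homo sapiens) for inhibition, read by trypan blue exclusion, with a stated time of 96 h; a higher number here means a weaker inhibitor of growth, a lower number a stronger inhibitor of growth:

- Compound 1 `Cc1ccc(S/C(=C/c2ccc(N(C)C)cc2)C(=O)c2ccc(Cl)cc2)cc1`: > 100000 nM, a limit.
- Compound 2 `Cc1ccc(S/C(=C/c2c(O)cc(O)cc2O)C(=O)c2ccc(Cl)cc2)cc1`: > 100000 nM, a limit.
- Compound 3 `CN(C)c1ccc(/C=C(\C(=O)c2ccc(Cl)cc2)S(=O)(=O)c2ccc(Br)cc2)cc1`: > 100000 nM, a limit.

Compound 3 has no number, only the limit > 100000 nM. It shares that position with the other two compounds: the limit of > 100000 nM in this assay, at which 3 of the 3 values shown sit.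

The next compound to be read is compound 4 `O=C(/C(=C\c1c(O)cc(O)cc1O)S(=O)(=O)c1ccc(Br)cc1)c1ccc(Cl)cc1`. The change is 2,4,6-trihydroxyphenyl in place of 4-(dimethylamino)phenyl on a double-bonded chain carbon bound to a double-bonded chain carbon. The sulfonyl side and the rest of the core stay as in compound 3.

The closest measured precedent is the same exchange of groups on the (4-methylphenyl)sulfanyl member, a step that the two limits leave unreadable from compound 1 to compound 2. The exchange of the sulfur-bearing group, a step that the two limits leave unreadable from compound 1 to compound 3, bears on it less directly. Neither step has a readable size, so neither gives a direction or magnitude to carry over. For the measured compounds named here, no compound has yet given a number in this assay.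

The expectation therefore rests on the limit shared by all three neighbours, and no readable shift is expected in either direction. The expected step is a number no higher from compound 3 to compound 4 (the limit leaves the size open). For compound 4 the estimated value is 100000 nM, with an expected range of 15000 nM to 150000 nM.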

Compound 4, concentration for 50% growth inhibition: > 100000 nM
Compound 4 gave a limit, no number; the forecaster's own chance of this, stated with the estimate: 70%; the middle value sits exactly at the limit.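

Compound 4 gives only a limit, as do compound 2 and compound 3, so neither of its new steps from those two compounds can be read in this assay. All the compounds shown share one position: the limit of > 100000 nM in this assay, at which 4 of the 4 values shown sit.

The compounds shown leave open whether any change on the shared core brings a numerical growth-inhibition value in this assay.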